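This account rests on a few compounds, and the source may have more. Where it says the series, first, only, none or still open, it means among the compounds named here.

Working notes on the series. The shared core of compound 1 (`CC[C@H](C)[C@H](NC(=O)c1cccc(Cn2ccnc2)c1)C(=O)NS(=O)(=O)c1ccccc1`) carries, in an assay on HEK293 cells for displacement of a labelled ligand from Type-2 angiotensin II receptor (Homo sapiens), tested at 1 uM (a lower number here means a weaker effect, a higher number a stronger effect of the compound at the concentration tested), a read-out of 5%, a weak effect at the concentration tested. Compound 2 (`CCCCS(=O)(=O)NNC(=O)[C@@H](NC(=O)c1cccc(Cn2ccnc2)c1)[C@@H](C)CC`) shares that core but, in this assay, stands at "not determined" (no result reported), so no single number is available for it; the same holds for compound 3 (`CC[C@H](C)[C@H](NC(=O)c1cccc(Cn2ccnc2)c1)C(=O)NNC(=O)OC(C)(C)C`), where this assay stands at "not determined" (no result reported). Going by the values given here, the only number in the set is therefore the low read-out of compound 1.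

Compound 4 (`CC[C@H](C)[C@H](NC(=O)c1cccc(Cn2ccnc2)c1)C(=O)NO`) is not yet measured. Compared with compound 2 the change is hydroxy in place of (butylsulfonyl)amino on an amide-type nitrogen. Since compound 2 has no number, the step to compound 4 cannot be anchored on compound 2 itself; the expectation rests on compound 1, whose 5% is the only read-out, and no step beyond the usual scatter is expected from it. Compound 4 is expected to show about 6% in this assay, within a range from -5% to 20%.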

Compound 4, a percentage reported as inhibition, at one concentration (the size of the read-out at that concentration, not a potency): "not active" (no number reported)
For compound 4 the study gives words and no number, and the estimate cannot be compared.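

No step can be read between compound 2 and compound 4: neither carries a number in this assay. The compounds shown leave open how hydroxy and (butylsulfonyl)amino on an amide-type nitrogen compare in this read-out. No further data bear on the result.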